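The compounds below may be only part of what the source reports. "The series", "measured", "known", "first", "only" and "open" are said of these compounds alone.

Measured so far:
- compound 1, `CCCCCCCCC(=O)NCc1cc(I)c(O)c(OC)c1`: 126 nM
- compound 2, `CCCCCCCCC(=O)NCc1ccc(O)c(OC)c1I`: 3380 nM

Both compounds were tested in an assay on HEK293 cells for inhibition of transient receptor potential cation channel subfamily V member 1 (Homo sapiens); on this read-out higher numbers stand for weaker inhibition and lower numbers for stronger inhibition. Of the two numbers, compound 1 holds the lower one, and the gap to compound 2 is well beyond the usual scatter of repeated measurements, so compound 1 is the stronger inhibitor of this pair. The two share the same amide chain and the same hydroxy and methoxy groups on their aromatic ring; they differ only in where the iodine sits.

Compound 3, `CCCCCCCCC(=O)NCc1cc(Br)c(O)c(OC)c1`, has not yet been measured in this assay. It is built from compound 1 by a single change: bromo in place of iodo on an aromatic carbon. Everything else about the molecule is unchanged.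

Among the compounds with values here, no measured pair here differs only by a halogen swap, so there is no step from which to read the size of this change directly. Exchanging one halogen for another at the same place is usually a modest change, and so the expected step of a 2.0-fold higher number from compound 1 to compound 3 (0.30 log units; within the scatter) is small, with a slight lean towards a higher number. Compound 3 is therefore expected to give about 250 nM in this assay, with a likely range from 80 nM to 800 nM.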

Compound 3, half-maximal inhibitory concentration: 252 nM
The estimate for compound 3 lay 1.0-fold (0.00 log units) below the measured number; the range from low to high includes it.
By their numbers in this assay, from the lowest: compounds 1 and 3 (each within the scatter of the next); then compound 2.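

In this assay the exchange of iodo for bromo on this aromatic carbon, ortho to a hydroxy group, gives a 2.0-fold higher number from compound 1 to compound 3 (0.30 log units; within the scatter) and so leaves the two compounds within the usual scatter of repeated measurements. The earlier pair showed that the place of the iodine on the ring matters; this step adds that, at the place the iodine holds in compound 1, these two halogens cannot be told apart on this read-out. No measurement is available that would explain this result.

Going by these compounds, two halogens give only a narrow view of this position, so it remains open whether chloro, fluoro or a plain hydrogen on the same carbon would also stay within the scatter of compound 1, or whether the halogen can be dispensed with altogether. On these data alone, it is equally open how a quite different group at this place, such as an amine or a carboxylic acid, would read in this assay and whether bromo on the carbon that carries iodo in compound 2 would follow the iodo result.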